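Acetylpiperidine to dimethylimidazole on a limit-only baseline

A few compounds are considered here, and "the series" means these few. Any claim that something is new, unique, unknown or untested is made for them only; others in the source may bear on it.

Compound 2 `CC(=O)N1CCC(c2cnc(NCc3c(F)ccc4c3CCO4)c3cn[nH]c(=O)c23)CC1` stands only as a limit in a physicochemical assay for solubility, read by LC-MS, in phosphate buffer, with a stated time of 24 h, at pH 7.4 (on this read-out lower numbers stand for lower solubility and higher numbers for higher solubility), < 2000 nM.

Compound 3 `Cc1ncc(-c2cnc(NCc3c(F)ccc4c3CCO4)c3cn[nH]c(=O)c23)n1C` carries 1,2-dimethyl-1H-imidazol-5-yl in place of 1-acetylpiperidin-4-yl on an aromatic carbon.

For the measured compounds named here, the one measured step, a step that the limit leaves unreadable from compound 1 to compound 2, offers no size to carry over. Going by the values given here, the only firm number is that of compound 1 `Cn1cc(-c2cnc(NCc3c(F)ccc4c3CCO4)c3cn[nH]c(=O)c23)cn1`, 1000 nM, and the expectation is anchored there.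

The estimated change is a step that the limit leaves unreadable from compound 2 to compound 3, with no direction firmly expected.

Compound 3 is expected at 1500 nM, with an estimated range of 400 nM to 6000 nM.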

Compound 3, solubility: 15000 nM
The estimate for compound 3 lay 10-fold (1.00 log units) below the measured number, and the stated range ends below it.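

In this assay this position now has a step of readable size, a 15-fold higher number from compound 1 to compound 3 (1.18 log units; beyond the scatter), with 1,2-dimethyl-1H-imidazol-5-yl in place of 1-methyl-1H-pyrazol-4-yl. Replacing 1-acetylpiperidin-4-yl with the same group gives an at least 7.5-fold higher number from compound 2 to compound 3 (0.87 log units; beyond the scatter). The step from compound 1 to compound 2 cannot be read, and the step to compound 3 rests on a limit for compound 2: the limit of < 2000 nM in this assay, at which 1 of the 3 values shown sits.

Still open, going by these compounds, is how an imidazole lacking the 2-methyl group, a piperidine with a free amine or a carboxylic acid on this aromatic carbon would read in this assay. With so few compounds, the step cannot yet be tied to either methyl group or to the imidazole ring itself.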